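The source may report more compounds than this note shows. Statements on the series, on what has been measured and on what is new or still open speak of the compounds shown alone.

Measured so far:
compound 1 `CC1CCN(c2c(S(=O)(=O)c3ccc(F)cc3)cnc3ccc(F)cc23)CC1` — 87%
compound 2 `Cc1ccc2ncc(S(=O)(=O)c3ccc(F)c(Cl)c3)c(N3CCC(C)CC3)c2c1` — 93%

In an assay on isolated protein for displacement of a labelled ligand from metabotropic glutamate receptor 5 (Homo sapiens), with a stated time of 60 min, tested at 1 uM (on this read-out higher numbers stand for more inhibition at the one concentration tested (going by the name of the read-out) and lower numbers for less inhibition), compound 1 gives 87% and compound 2 gives 93%. Compound 2 carries the higher of the two numbers, but the gap to compound 1 is within the scatter, so the two cannot be told apart on this assay; both sit well toward the upper end of the scale. For the measured compounds named here, no pair of measured compounds differs in a single place, so no step between measured compounds is available as a guide.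

Compound 3 `CC1CCN(c2c(S(=O)(=O)c3ccc(F)c(Cl)c3)cnc3ccc(F)cc23)CC1` is not yet measured. It differs from compound 2 by fluoro in place of methyl on an aromatic carbon. With both measured numbers close together and high, no ground is given for a move beyond the scatter in either direction; the step from compound 2 to compound 3 is expected to be small, a number 5 percentage points lower from compound 2 to compound 3 (within the scatter), and to fall inside the usual spread of repeated measurements. On that basis compound 3 is estimated at 88% in this assay, with a likely range from 75% to 97%.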

Compound 3, a percentage reported as inhibition, at one concentration (the size of the read-out at that concentration, not a potency): 95%
Estimate against measurement, compound 3: 7 percentage points below; low and high end bracket the measured number.
By their numbers in this assay, from the lowest: compounds 1, 2 and 3 (each within the scatter of the next).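

In this assay, fluoro in place of methyl on an aromatic carbon, meta to a fused ring and para to a fused ring, gives a number 2 percentage points higher from compound 2 to compound 3 (within the scatter), so these two small groups cannot be told apart at this position. Chloro in place of hydrogen on an aromatic carbon gives a number 8 percentage points higher from compound 1 to compound 3 (within the scatter), so that change cannot be told apart from no change on this read-out, and the pair adds a second single-place comparison to the series. No measurement shown here offers a cause for either step.

The compounds shown leave open whether a methoxy, an amine or a carboxylic acid at the position of the fluoro and methyl groups would stay within the scatter of compound 3, since only two small groups have been compared there. They also leave open whether compounds that cannot be separated at the one concentration tested would differ in potency, since all three numbers sit toward the upper end of the scale.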